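The source may report more compounds than this note shows. Statements on the series, on what has been measured and on what is new or still open speak of the compounds shown alone.

Measured in an ADME assay on HEp-2 cells (Homo sapiens) for cytotoxicity; on this read-out higher numbers stand for lower toxicity in this test and lower numbers for higher toxicity in this test:
compound 1, `CNCc1ccc2c(c1)nc(Cn1c(=O)n(C(C)C)c3ccccc31)n2CCC(C)C`: 1480 nM
compound 2, `CC(C)CCn1c(Cn2c(=O)n(C(C)C)c3ccccc32)nc2ccc(CN(C)C)cc21`: 26700 nM

Compound 1 stands at the lowest of the two numbers; compound 2 sits at the higher number, a gap beyond the scatter. Compound 3, `COC(=O)c1ccc2c(c1)nc(Cn1c(=O)n(C(C)C)c3ccccc31)n2CCC(C)C`, has not been measured. It differs from compound 1 in one place: methoxycarbonyl in place of (methylamino)methyl on an aromatic carbon. Methoxycarbonyl enters on the aromatic carbon where (methylamino)methyl stood. For the measured compounds named here, no measured step covers such a change, so the expectation rests on compound 1 alone. A moderate step upward is expected, a 5.4-fold higher number from compound 1 to compound 3 (0.73 log units; beyond the scatter), with the direction uncertain. For compound 3 the estimate is 8000 nM, within 1500 nM to 40000 nM.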

Compound 3, half-maximal cytotoxic concentration: 33700 nM
The estimate for compound 3 lay 4.2-fold (0.62 log units) below the measured number; the measured number falls inside the stated range.
By their numbers in this assay, from the lowest: compound 1; then compounds 2 and 3 (each within the scatter of the next).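

Methoxycarbonyl in place of (methylamino)methyl on this aromatic carbon gives a 23-fold higher number from compound 1 to compound 3 (1.36 log units; beyond the scatter) in this assay. The read-out at this position therefore responds strongly to the group held there, and a basic-free... 

Correction to the working note above: the read-out in this series therefore responds strongly to the group on this aromatic carbon, with the rest of the core of compound 1 unchanged. No available evidence accounts for this step. Still open, going by these compounds, is whether a carboxylic acid or a primary amide on this carbon gives a number close to that of compound 3. Also open, on these data alone, is how a simple primary amine or a longer aminoalkyl chain would fall relative to compound 1.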